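The source may report more compounds than this note shows. Statements on the series, on what has been measured and on what is new or still open speak of the compounds shown alone.

Measured compounds:
- compound 1 `Clc1ccncc1C1=CC2CNCC(C1)C2`: 3 nM
- compound 2 `COc1ccccc1Oc1cncc(C2=CC3CNCC(C2)C3)c1`: 1 nM

In an in vitro assay on SH-EP1 cells for displacement of a labelled ligand from Neuronal acetylcholine receptor; alpha4/beta2 (Homo sapiens) (on this read-out lower numbers stand for stronger inhibition and higher numbers for weaker inhibition), compound 2 gives 1 nM, the lower of the two numbers; compound 1, at 3 nM, stands beyond the scatter above it. Compound 3 `COc1ccc(Oc2cncc(C3=CC4CNCC(C3)C4)c2)cc1` differs from compound 2 by 4-methoxyphenyl in place of 2-methoxyphenyl on an oxygen on an aromatic ring. Within the data shown here, no measured pair shows this change, so its size is unknown. In this assay the step from compound 2 to compound 3 is expected to stay within the scatter, or at most to weaken binding slightly: a 2.0-fold higher number from compound 2 to compound 3 (0.30 log units; within the scatter). For compound 3 the estimate in this assay is 2 nM, in the range 0.5 nM to 8 nM.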

Compound 3, inhibition constant: 1.4 nM
Compound 3: the middle estimate sits 1.4-fold (0.15 log units) above what was measured; measured number inside the range.
By their numbers in this assay, from the lowest: compounds 2 and 3 (each within the scatter of the next); then compound 1.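

In this assay, among these compounds, the exchange of 2-methoxyphenyl for 4-methoxyphenyl on an oxygen on an aromatic ring gives a 1.4-fold higher number from compound 2 to compound 3 (0.15 log units; within the scatter) and is the first step readable. At this position, the read-out does not separate these two methoxyphenyl groups. No supporting data bear on why the two compounds stand level.

The compounds shown leave open how a 3-methoxyphenyl group, a plain phenyl or a phenyl carrying a carboxylic acid would read on this oxygen. As far as these compounds go, a primary amine in place of the methoxy group also remains open.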